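The compounds below may be only part of what the source reports. "The series", "measured", "known", "first", "only" and "open" are said of these compounds alone.

Measured compounds:
compound 1 `COc1ccc(-c2cc(=O)c3c(OC)cc(OC)cc3[nH]2)cc1`: > 31100 nM
compound 2 `COc1ccc(-c2cc(=O)c3c(OC)cc(OC)cc3n2C)cc1`: 26000 nM
compound 3 `COC(=O)c1cc(=O)c2c(OC)cc(OC)cc2[nH]1`: > 34400 nM

In a functional assay on SEM cells (Homo sapiens) for antiproliferative activity, with a stated time of 72 h (a higher number here means that more compound is needed for the effect, a lower number that less compound is needed), compound 1 reaches only a limit of the assay, > 31100 nM. Compound 2 gives 26000 nM in this assay. The change between them is methyl in place of hydrogen on an aromatic nitrogen, and it makes an at least 1.1-fold lower number from compound 1 to compound 2 (0.07 log units; that floor lies within the scatter), a step whose floor rests on the limit (the limit of > 31100 nM in this assay, at which 1 of the 3 values shown sits). Compound 3 also reaches only a limit in this assay, > 34400 nM. How the core of compound 3 differs from that of compound 1 is not broken down here.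

Compound 4 `COC(=O)c1cc(=O)c2c(OC)cc(OC)cc2n1C` is not yet measured. It differs from compound 3 by methyl in place of hydrogen on an aromatic nitrogen, the same kind of change as from compound 1 to compound 2, but the aromatic nitrogen here is ortho to a methoxycarbonyl group, whereas in compound 1 it is ortho to a 4-methoxyphenyl group. Compound 4 is expected to show a step that the limit leaves unreadable from compound 3 to compound 4, an expectation that rests on the small step of an at least 1.1-fold lower number from compound 1 to compound 2 (0.07 log units; that floor lies within the scatter) and on the fact that compound 3 sits at the limit (the limit of > 34400 nM in this assay, at which 1 of the 3 values shown sits). Compound 4 is therefore estimated at 40000 nM, between 15000 nM and 150000 nM.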

Compound 4, half-maximal effective concentration: > 19000 nM
Compound 4: only a limit was reported (the forecaster's own chance of this, stated with the estimate: 70%); the middle value is on the limit's open side.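

Compound 4 reaches only a limit in this assay, > 19000 nM. No new step can therefore be read from compound 3 to compound 4 or from compound 2 to compound 4: the limit of > 19000 nM in this assay, at which 1 of the 4 values shown sits.

The compounds shown leave open whether methyl in place of hydrogen on the aromatic nitrogen changes the number at all in the methoxycarbonyl series, and how methoxycarbonyl compares with 4-methoxyphenyl.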